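Capping the free hydroxy of compound 2

The source may hold more compounds than are shown below. What is called first, only, known or untested is meant among the compounds shown, and "the series" means these compounds.

In a functional assay on MDA-MB-231 cells (Homo sapiens) for antiproliferative activity, read by MTT assay, with a stated time of 48 h (on this read-out higher numbers stand for weaker inhibition of growth and lower numbers for stronger inhibition of growth), compound 1 `COc1cc(/C=C2\Cc3cc(OC)c(OC)c(OC)c3C2=O)cc(OC)c1OC` gives > 10000 nM, a limit and not a number. Compound 2 `COc1cc2c(cc1O)C(=O)/C(=C/c1cc(OC)c(OC)c(OC)c1)C2` gives > 10000 nM, again a limit. Among the compounds with values here, both compounds therefore stand at the limit of > 10000 nM in this assay, at which 2 of the 2 values shown sit, and no measured step links them. Compound 3 `COc1cc2c(cc1OC)C(=O)/C(=C/c1cc(OC)c(OC)c(OC)c1)C2` differs from compound 2 by methyl in place of hydrogen on an oxygen on an aromatic ring, hydroxy to methoxy. In this assay, no change beyond the scatter is expected, and another reading at the limit seems likely. The expected step of a number no higher from compound 2 to compound 3 (the limit leaves the size open) is small. Compound 3 is estimated at 10000 nM, with a range of 2000 nM to 30000 nM.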

Compound 3, concentration for 50% growth inhibition: > 10000 nM
Compound 3: no number, only a limit (the forecaster's own chance of this, stated with the estimate: 70%); the middle value lies on the limit itself.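

In this assay compound 3 gives > 10000 nM, a limit and not a number. The steps to compound 3 from compound 1 and from compound 2 therefore cannot be read: the limit of > 10000 nM in this assay, at which 3 of the 3 values shown sit.

The compounds shown leave open whether replacing the hydroxy of compound 2 with methoxy changes growth inhibition at all.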